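Swapping the Methylphenyl for an Aminophenyl in a Urea

This account rests on a few compounds, and the source may have more. Where it says the series, first, only, none or still open, it means among the compounds named here.

Compound 1 `Cc1ccccc1C1(CNC(=O)Nc2c(C(C)C)cccc2C(C)C)CCCC1`: 17 nM
Compound 2 `CC(C)c1cccc(C(C)C)c1NC(=O)NCC1(c2ccc([N+](=O)[O-])cc2)CCCC1`: 131 nM

Compound 1 stands lowest of the two numbers in an assay on microsomes for inhibition of acyl-CoA:cholesterol acyltransferase (Oryctolagus cuniculus); a higher number here means a weaker inhibitor, a lower number a stronger inhibitor. Compound 3 `CC(C)c1cccc(C(C)C)c1NC(=O)NCC1(c2ccc(N)cc2)CCCC1` differs from it in one place: 4-aminophenyl in place of 2-methylphenyl on a saturated ring carbon. Among the measured compounds shown here, only one measured step bears on this change, a 7.7-fold higher number from compound 1 to compound 2 (0.89 log units; beyond the scatter), where the 2-methylphenyl on the same saturated ring carbon was also replaced by a phenyl bearing a substituent on its ring, and inhibition weakened modestly. A weakening of similar size is therefore expected, a 5.9-fold higher number from compound 1 to compound 3 (0.77 log units; beyond the scatter). Compound 3 is accordingly estimated at 100 nM, within a range of 30 nM to 350 nM.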

Compound 3, half-maximal inhibitory concentration: 29 nM
Beside the measured number, compound 3's estimate is 3.4-fold (0.54 log units) above it; the whole stated range lies above it.
By their numbers in this assay, from the lowest: compounds 1 and 3 (each within the scatter of the next); then compound 2.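

In this assay, a phenyl bearing a substituent on this saturated ring carbon need not cost inhibition: 4-aminophenyl in place of 2-methylphenyl gives (a 1.7-fold higher number from compound 1 to compound 3 (0.23 log units; within the scatter)), a change that cannot be told from scatter. The weakening seen with 4-nitrophenyl therefore belongs to that group and not to every such swap, as amino in place of nitro gives (a 4.5-fold lower number from compound 2 to compound 3 (0.65 log units; beyond the scatter)). No evidence here explains this difference.

The swap changes both the group and where it sits on the phenyl, so these two changes remain unseparated. A 4-methylphenyl or 2-aminophenyl would pull them apart, and a dimethylamino or carboxylic acid would test how much change the amino position tolerates.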